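This account rests on a few compounds, and the source may have more. Where it says the series, first, only, none or still open, it means among the compounds named here.

Measured in a functional assay on OVCAR-3 cells (Homo sapiens) for inhibition, read by MTT assay, with a stated time of 24 h; on this read-out lower numbers stand for stronger inhibition and higher numbers for weaker inhibition:
- compound 1 `CC1(C)[C@H]2CC[C@]1(C)N(Cc1cn(-c3ccc(F)cc3)nn1)C(=O)C2`: 200 nM
- compound 2 `Cc1ccc(-n2cc(CN3C(=O)C[C@@H]4CC[C@@]3(C)C4(C)C)nn2)cc1`: 40 nM
- compound 3 `Cc1ccccc1-n1cc(CN2C(=O)C[C@@H]3CC[C@@]2(C)C3(C)C)nn1`: 150 nM

Compound 3 gives 150 nM, the second highest of the three numbers. The measured steps place it close to one neighbour, with a 1.3-fold lower number from compound 1 to compound 3 (0.12 log units; within the scatter), and clearly apart from the other, with a 3.8-fold higher number from compound 2 to compound 3 (0.57 log units; beyond the scatter).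

Compound 4 `Cc1cccc(-n2cc(CN3C(=O)C[C@@H]4CC[C@@]3(C)C4(C)C)nn2)c1` has the same atoms as compound 3, joined differently: 3-methylphenyl in place of 2-methylphenyl on an aromatic nitrogen, (3-methylphenyl in place of 2-methylphenyl on an aromatic nitrogen).

The closest evidence is the exchange between the two methylphenyl isomers already measured, which shows a 3.8-fold higher number from compound 2 to compound 3 (0.57 log units; beyond the scatter). The step of a 5.0-fold lower number from compound 1 to compound 2 (0.70 log units; beyond the scatter) also bears on it, since it shows what a methyl group in place of fluoro did on the same aryl ring. Neither step tests the 3-methylphenyl group itself, so the series gives only a rough guide. The expectation rests on compound 2, at 40 nM, and on compound 3, at 150 nM, with compound 4 expected to fall between these two values. In this assay a modest move to a lower number is therefore expected, smaller than the step between the two isomers. The expected step is a 1.9-fold lower number from compound 3 to compound 4 (0.27 log units; within the scatter). The estimate for compound 4 is 80 nM, with an expected range from 30 nM to 210 nM.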

Compound 4, half-maximal inhibitory concentration: 160 nM
The estimate for compound 4 lay 2.0-fold (0.30 log units) below the measured number, within the range that was stated.
By their numbers in this assay, from the lowest: compound 2; then compounds 3, 4 and 1 (each within the scatter of the next).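

In this assay, moving the methyl around the phenyl ring does not always separate the isomers: a 1.1-fold higher number from compound 3 to compound 4 (0.03 log units; within the scatter) shows that the 3-methylphenyl and 2-methylphenyl groups on the aromatic nitrogen cannot be told apart. The new compound also shows that the 4-methylphenyl group alone stands apart among the three methylphenyl isomers, since a 4.0-fold higher number from compound 2 to compound 4 (0.60 log units; beyond the scatter) lies beyond the scatter. The step already seen between the other two isomers (a 3.8-fold higher number from compound 2 to compound 3 (0.57 log units; beyond the scatter)) is close to it in size. Compound 4 cannot be told apart from the 4-fluorophenyl compound either, as a 1.3-fold lower number from compound 1 to compound 4 (0.10 log units; within the scatter) shows, so among these compounds a methyl on the phenyl ring gives a clearly lower number only in the 4-methylphenyl group.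

The compounds shown leave open whether another group in the place of that methyl, such as ethyl, methoxy or chloro, would keep the number of compound 2 or return it to the level of the other three. Nothing available explains why the 4-methylphenyl group differs from its two isomers.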